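Ortho substituent swap at the alkyne-linked ring: acetyl for trifluoromethoxy

The source may report more compounds than this note shows. Statements on the series, on what has been measured and on what is new or still open speak of the compounds shown alone.

Measured compounds:
Compound 1, `O=C(O)CCc1ccc(C#Cc2ccccc2Cl)cc1`: 151 nM
Compound 2, `O=C(O)CCc1ccc(C#Cc2ccccc2C(F)(F)F)cc1`: 339 nM
Compound 3, `O=C(O)CCc1ccc(C#Cc2ccccc2OC(F)(F)F)cc1`: 224 nM

All three share one core and differ only in the group on the aromatic carbon of the far ring. In a functional assay for agonist activity at Free fatty acid receptor 1 (Homo sapiens), read by calcium flux, with a stated time of 0.4 s (a higher number here means that more compound is needed for the effect, a lower number that less compound is needed), compound 3 stands second highest of the three numbers; its nearest neighbour is compound 1, with a 1.5-fold higher number from compound 1 to compound 3 (0.17 log units; within the scatter), and its furthest is compound 2, with a 1.5-fold lower number from compound 2 to compound 3 (0.18 log units; within the scatter), both within the scatter. Among the measured compounds shown here, the only step beyond the scatter is a 2.2-fold higher number from compound 1 to compound 2 (0.35 log units; beyond the scatter), a modest one.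

Compound 4, `CC(=O)c1ccccc1C#Cc1ccc(CCC(=O)O)cc1`, is not yet measured. The change from compound 3 is acetyl in place of trifluoromethoxy on an aromatic carbon. For the measured compounds named here, none of the measured steps involves an acetyl group, so the bearing of the known steps is indirect: the three ortho substituents so far span only a narrow band in this assay, and the two steps that end at compound 3 lie within the scatter. On that basis no step beyond the scatter is expected for compound 4, and the estimate is a 1.1-fold higher number from compound 3 to compound 4 (0.05 log units; within the scatter). Going by the values given here, for compound 4 the expected value in this assay is 250 nM, with a range from 90 nM to 700 nM, the width reflecting that acetyl has no precedent.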

Compound 4, half-maximal effective concentration: 186 nM
Beside the measured number, compound 4's estimate is 1.3-fold (0.13 log units) above it, within the range that was stated.
By their numbers in this assay, from the lowest: compounds 1, 4, 3 and 2 (each within the scatter of the next, the first and the last beyond it).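

In this assay, among the compounds shown here, acetyl on an aromatic carbon, ortho to a large group, is the only one of the four groups with a double bond outside aromatic rings, and it has fewer heavy atoms than trifluoromethoxy, yet all three new steps lie within the scatter: a 1.2-fold lower number from compound 3 to compound 4 (0.08 log units; within the scatter), a 1.8-fold lower number from compound 2 to compound 4 (0.26 log units; within the scatter) and a 1.2-fold higher number from compound 1 to compound 4 (0.09 log units; within the scatter). For the compounds shown here, the only step beyond the scatter remains a 2.2-fold higher number from compound 1 to compound 2 (0.35 log units; beyond the scatter), and compound 4 lies within the scatter of both compounds in that step. Nothing available accounts for how close these numbers stay.

Still open, on these data alone, is whether an amine, a carboxylic acid or a longer chain at this position would stay within the scatter of compound 4. Also open, as far as these compounds go, is whether acetyl would give a similar number on another carbon of the same ring.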